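A few compounds are considered here, and "the series" means these few. Any claim that something is new, unique, unknown or untested is made for them only; others in the source may bear on it.

Compound 1 `COc1cc(-c2nnc3c(OC)cc(-c4ccc5[nH]cc(C=O)c5c4)cn23)cc(OC)c1OC` | > 10000 nM (a limit of the assay)
Compound 2 `COc1cc(-c2nnc3c(OC)cc(-c4ccc5c(ccn5C)c4)cn23)cc(OC)c1OC` | 69 nM

For the measured compounds named here, both compounds were tested in a functional assay on A549 cells (Homo sapiens) for antiproliferative activity, read by MTT assay, with a stated time of 48 h (on this read-out higher numbers stand for weaker inhibition and lower numbers for stronger inhibition), and compound 2 holds the only actual number, since the entry for compound 1 is a limit. Compound 3 `COc1cc(-c2nnc3c(OC)cc(-c4ccc5c(c4)c(C=O)cn5C)cn23)cc(OC)c1OC` differs from compound 2 by formyl in place of hydrogen on an aromatic carbon and by nothing else. Going by the values given here, the one measured step that bears on this is large, an at least 140-fold lower number from compound 1 to compound 2 (2.16 log units; beyond the scatter) and it also loses a formyl group, but it exchanges the whole 3-formyl-1H-indol-5-yl for 1-methyl-1H-indol-5-yl, so formyl alone may account for only part of it. A smaller step towards weaker inhibition is therefore expected, estimated as a 10-fold higher number from compound 2 to compound 3 (1.01 log units; beyond the scatter) in this assay overall. For compound 3 the estimated value is 700 nM with an expected range from 100 nM to 6000 nM in the same test.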

Compound 3, half-maximal inhibitory concentration: 3080 nM
The estimate for compound 3 lay 4.4-fold (0.64 log units) below the measured number, and the stated range covers the measured number.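

In this assay, for the compounds shown here, formyl in place of hydrogen on this aromatic carbon, as the only change, gives a 45-fold higher number from compound 2 to compound 3 (1.65 log units; beyond the scatter), so this single group brings a large loss of inhibition even with the ring nitrogen methylated. With formyl kept, methyl in place of hydrogen on the ring nitrogen gives an at least 3.2-fold lower number from compound 1 to compound 3 (0.51 log units; beyond the scatter), so the nitrogen substituent matters too. Compound 1 holds only a limit: the limit of > 10000 nM in this assay, at which 1 of the 3 values shown sits.

As far as these compounds go, whether an aminomethyl group or a carboxylic acid on this carbon would behave like formyl stays open. So does the outcome of an ethyl group in place of methyl on the ring nitrogen.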